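The source may hold more compounds than are shown below. What is called first, only, known or untested is meant among the compounds shown, and "the series" means these compounds.

Working notes on the series. The shared core is that of compound 1 `Cc1nc(-c2cccnc2)sc1-c1nnc(-c2ccccc2)o1`; compound 2 `Cc1nc(-c2cccnc2)sc1-c1nnc(Cc2ccccc2)o1` and compound 3 `Cc1cccc(-c2nnc(-c3sc(-c4cccnc4)nc3C)o2)c1` are its variants at the same position. In an ADME assay on HeLa cells (Homo sapiens) for cytotoxicity, read by MTT assay (on this read-out higher numbers stand for lower toxicity in this test and lower numbers for higher toxicity in this test), compound 1 gives only a limit of the assay, > 100 ug/mL. Compound 2 likewise gives only a limit in this assay, > 100 ug/mL. Compound 3 also stands at a limit in this assay, > 100 ug/mL. All three values sit at the limit of > 100 ug/mL in this assay, at which 3 of the 3 values shown sit, so compound 3 cannot be placed above or below the other two on these numbers. Accordingly the steps a step that the two limits leave unreadable from compound 1 to compound 2, a step that the two limits leave unreadable from compound 1 to compound 3 and a step that the two limits leave unreadable from compound 2 to compound 3 are of unreadable size. Compound 4 `Cc1nc(-c2cccnc2)sc1-c1nnc(-c2ccc(O)cc2)o1` differs from compound 3 in one place: 4-hydroxyphenyl in place of 3-methylphenyl on an aromatic carbon. Going by the values given here, the measured steps bear on this change only in that no exchange at this position has so far brought a value inside the measurable range; no size of step is readable from them. Compound 4 is therefore expected to give 150 ug/mL in this assay, with a range from 60 ug/mL to 400 ug/mL, most likely again as a limit. The expected step is a step that the limit leaves unreadable from compound 3 to compound 4, none beyond the scatter.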

Compound 4, half-maximal cytotoxic concentration: > 100 ug/mL
Compound 4 gave a limit, no number; the forecaster's own chance of this, stated with the estimate: 80%; the middle value does not contradict the limit.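

In this assay, going by these compounds alone, compound 4 also gives only a limit, so no step between it and compound 1, compound 2 or compound 3 can be read: the limit of > 100 ug/mL in this assay, at which 4 of the 4 values shown sit. The compounds shown leave open how far any exchange at this position shifts the half-maximal cytotoxic concentration, and whether any exchange brings it inside the measurable range.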